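A few compounds are considered here, and "the series" means these few. Any claim that something is new, unique, unknown or untested is made for them only; others in the source may bear on it.

Measured in an in vitro ADME assay on microsomes from liver (Simiiformes); a higher number here means that the compound lasts longer, a lower number that the compound disappears faster:
compound 1 `COCc1cc(CCCOc2c(C)cc(-c3noc(C(F)(F)F)n3)cc2C)on1`: 1.58 h
compound 2 `CCOCc1cc(CCCOc2c(C)cc(-c3noc(C(F)(F)F)n3)cc2C)on1`: > 2.5 h (a limit)
compound 3 `Cc1cc(-c2noc(C(F)(F)F)n2)cc(C)c1OCCCc1cc(CS(C)(=O)=O)no1`: > 2.5 h (a limit)

Compound 3 stands at the limit of > 2.5 h in this assay, at which 2 of the 3 values shown sit, so only a limit is known for it. Next comes compound 4 `Cc1cc(-c2noc(C(F)(F)F)n2)cc(C)c1OCCCc1cccc(F)n1`, with 6-fluoropyridin-2-yl in place of 3-((methylsulfonyl)methyl)-1,2-oxazol-5-yl on a saturated chain carbon, three bonds along the chain from an oxygen on an aromatic ring.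

Going by the values given here, no measured step makes this exchange. The closest are an at least 1.5-fold higher number from compound 1 to compound 2 (0.19 log units; that floor lies within the scatter), an at least 1.5-fold higher number from compound 1 to compound 3 (0.19 log units; that floor lies within the scatter) and a step that the two limits leave unreadable from compound 2 to compound 3, and these alter only the side chain of the group that leaves here. Among the compounds with values here, the one number is compound 1 at 1.58 h, so that value anchors the expectation in this assay. The expected change is an at least 1.6-fold lower number from compound 3 to compound 4 (0.22 log units; that floor lies within the scatter), a moderate fall with wide uncertainty. The estimate for compound 4 is 1.5 h, with an expected range of 0.6 h to 3 h.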

Compound 4, half-life: > 2.5 h
Compound 4 was reported as a limit; the forecaster's own chance of this, stated with the estimate: 20%; middle value at least 1.6-fold (0.22 log units) from the limit.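

In this assay compound 4 gives > 2.5 h, a limit. With 6-fluoropyridin-2-yl in place of 3-(methoxymethyl)-1,2-oxazol-5-yl, the series shows an at least 1.5-fold higher number from compound 1 to compound 4 (0.19 log units; that floor lies within the scatter), so exchanging the whole ring group, not only its side chain, leaves no loss visible at this place. The steps to compound 4 from compound 2 and from compound 3 cannot be read: the limit of > 2.5 h in this assay, at which 3 of the 4 values shown sit.

As far as these compounds go, how far compound 2, compound 3 and compound 4 lie apart stays unknown. From the compounds shown here alone, whether an amine in place of the fluorine of 6-fluoropyridin-2-yl, or a longer chain at this place, would bring the half-life back within the measurable range also stays open.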